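Swapping the acyl group on the ring nitrogen of compound 2

The source may report more compounds than this note shows. Statements on the series, on what has been measured and on what is new or still open speak of the compounds shown alone.

Measured so far:
compound 1 `Cc1nc(S(C)(=O)=O)ccc1Oc1ncnc(OC2CCN(C(=O)OC(C)(C)C#N)CC2)c1F` — 92.9 nM
compound 2 `Cc1nc(S(C)(=O)=O)ccc1Oc1ncnc(OC2CCN(C(=O)C(F)(F)F)CC2)c1F` — 151 nM

Within the data shown here, in a functional assay on isolated protein for inhibition of Glucose-dependent insulinotropic receptor (Homo sapiens), read by HTRF and cAMP accumulation (on this read-out lower numbers stand for an effect already at smaller amounts and higher numbers for an effect only at larger amounts of compound), compound 2 gives 151 nM, and the only other measured compound, compound 1, gives 92.9 nM, so that a 1.6-fold higher number from compound 1 to compound 2 (0.21 log units; within the scatter). Compound 3 `Cc1nc(S(C)(=O)=O)ccc1Oc1ncnc(OC2CCN(C(=O)c3noc(C(C)C)n3)CC2)c1F` is not yet measured. It differs from compound 2 in that (5-isopropyl-1,2,4-oxadiazol-3-yl in place of trifluoromethyl on a carbonyl carbon). Among the measured compounds shown here, the one step already seen, a 1.6-fold higher number from compound 1 to compound 2 (0.21 log units; within the scatter), also exchanged the group on this carbonyl carbon and stayed within the scatter. The number for compound 3 is therefore expected near that of compound 2, with a 1.3-fold lower number from compound 2 to compound 3 (0.10 log units; within the scatter), giving an estimate of 120 nM ranging from 40 nM to 400 nM.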

Compound 3, half-maximal effective concentration: 21.2 nM
Compound 3: middle estimate off by 5.7-fold (0.75 log units), on the high side, and the stated range ends above it.
By their numbers in this assay, from the lowest: compound 3; then compounds 1 and 2 (each within the scatter of the next).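

Placing 5-isopropyl-1,2,4-oxadiazol-3-yl on this carbonyl carbon brings a 7.1-fold lower number from compound 2 to compound 3 (0.85 log units; beyond the scatter) and a 4.4-fold lower number from compound 1 to compound 3 (0.64 log units; beyond the scatter) in this assay while the earlier exchange at this place stayed within the scatter. The choice of group here can therefore shift the number clearly, and the aromatic ring with its isopropyl group gives the lowest number of the three. Nothing measured here accounts for this gain. Going by these compounds, it remains open whether the isopropyl group contributes to the gain or the ring alone is enough. A methyl group on the same ring, or a plain phenyl ring in its place, would begin to separate the two.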